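The source may report more compounds than this note shows. Statements on the series, on what has been measured and on what is new or still open speak of the compounds shown alone.

In a functional assay on MDA-MB-231 cells (Homo sapiens) for cytotoxicity, read by neutral red uptake, with a stated time of 72 h (on this read-out higher numbers stand for weaker inhibition and lower numbers for stronger inhibition), three compounds have been measured. Compound 1 `CCCCCNc1nc(NCCCCC)c2ccccc2n1` gives 3130 nM. Compound 3 `Clc1ccc(CNc2nc(NCc3ccc(Cl)cc3)c3cccnc3n2)cc1` gives 8300 nM. Compound 2 `CCNc1nc(SCC)nc2ncccc12` gives 18700 nM, the highest number of the three, so on this read-out it is the weakest inhibitor of the set: its gap to compound 3 and its larger gap to compound 1 both lie beyond the usual scatter. None of these three compounds differs from another in only one place, so no single step between measured compounds is shown.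

Compound 4 `CCCCNc1nc(SCC)nc2ncccc12` has not yet been measured in this assay. It differs from compound 2 in a single way: ethyl in place of hydrogen on a saturated chain carbon, two bonds along the chain from a nitrogen on an aromatic ring. Everything else is kept as in compound 2. Going by the values given here, no measured pair shows exactly this step, so the expectation rests on the three numbers alone. From compound 2 to compound 4 a modest step toward a lower number is expected, a 1.6-fold lower number from compound 2 to compound 4 (0.19 log units; within the scatter), though a result within the scatter of compound 2 would not surprise. The value estimated for compound 4 in this assay is 12000 nM, with a range from 4000 nM to 40000 nM.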

Compound 4, half-maximal inhibitory concentration: 9200 nM
Beside the measured number, compound 4's estimate is 1.3-fold (0.12 log units) above it; low and high end bracket the measured number.
By their numbers in this assay, from the lowest: compound 1; then compounds 3 and 4 (each within the scatter of the next); then compound 2.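

Changing ethylamino to butylamino, with ethyl in place of hydrogen on a saturated chain carbon, two bonds along the chain from a nitrogen on an aromatic ring, gives in this assay a 2.0-fold lower number from compound 2 to compound 4 (0.31 log units; beyond the scatter). Going by these compounds alone, this is the first comparison here in which only one place changes, and it shows that this chain position accepts the added ethyl without a rise in the number, with a modest fall instead. Nothing shown explains why the number falls.

A single step cannot show whether the number would keep falling with a longer chain such as hexylamino, or whether it would level off or rise again. It also leaves open how a branched group such as isobutylamino or a ring such as cyclohexylamino would read at this place.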